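Three Aryl Variants Measured, a Fourth Still Open

A few compounds are considered here, and "the series" means these few. Any claim that something is new, unique, unknown or untested is made for them only; others in the source may bear on it.

Of the compounds shown here, three that share one core have been measured in an assay on Sf9 cells for inhibition of protein deacetylase HDAC6 (Homo sapiens), read by fluorescence, with a stated time of 40 min, tested at 100 nM; on this read-out higher numbers stand for more inhibition at the one concentration tested (going by the name of the read-out) and lower numbers for less inhibition. Compound 1 `O=C(NO)c1ccc(NCc2nc(-c3ccc(Cl)cc3)nn2-c2ccccc2)cc1` gives 67.2% in this assay. Compound 2 `O=C(NO)c1ccc(NCc2nc(-c3ccc(F)cc3)nn2-c2ccccc2)cc1` gives 70.9% in this assay. Compound 3 `O=C(NO)c1ccc(NCc2nc(-c3cc4ccccc4s3)nn2-c2ccccc2)cc1` gives 65.5% in this assay, which is the lowest of the three numbers, yet both of its steps to the others stay within the scatter: a number 1.7 percentage points lower from compound 1 to compound 3 (within the scatter) and a number 5.4 percentage points lower from compound 2 to compound 3 (within the scatter). The remaining pair behaves the same way, since a number 3.7 percentage points higher from compound 1 to compound 2 (within the scatter). On these numbers, then, the three measured compounds cannot be told apart.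

Compound 4 `Cc1cccc(-c2nc(CNc3ccc(C(=O)NO)cc3)n(-c3ccccc3)n2)c1` has not yet been measured in this assay. It differs from compound 3 at a single place: 3-methylphenyl in place of 1-benzothiophen-2-yl on an aromatic carbon. The two measured steps that bear on this change are the ones reaching compound 3 from compound 1 and from compound 2, where the group at this same position was exchanged, and both of those steps were within the scatter. The expectation is therefore no step beyond the scatter in this assay. Compound 4 is expected to give about 67% in this assay, with a likely range from 55% to 78%. This estimate means a step of a number 1.5 percentage points higher from compound 3 to compound 4 (within the scatter), which is expected to remain within the scatter.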

Compound 4, a percentage reported as inhibition, at one concentration (the size of the read-out at that concentration, not a potency): 64.1%
For compound 4 the middle estimate is 2.9 percentage points above the measured one; low and high end bracket the measured number.
By their numbers in this assay, from the lowest: compounds 4, 3, 1 and 2 (each within the scatter of the next).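

In this assay, the step at this ring carbon between two ring nitrogen atoms is a number 1.4 percentage points lower from compound 3 to compound 4 (within the scatter), even though a single six-membered ring of carbon with a methyl group replaces a fused two-ring group containing sulfur. Compound 4 is also the first compound shown with neither a halogen nor a sulfur atom on this aryl group, and the comparisons with the halogenated compounds give a number 6.8 percentage points lower from compound 2 to compound 4 (within the scatter) and a number 3.1 percentage points lower from compound 1 to compound 4 (within the scatter), so among these four compounds all three exchanges at this position stay within the scatter. No supporting data explain why these aryl groups give such similar numbers.

All four groups shown at this position are aromatic, so it remains open whether an amine, a carboxylic acid or a plain butyl chain there would give a number in the same range. The read-out also reports inhibition at one concentration rather than a potency, which leaves open whether full concentration-response measurements would separate these four compounds.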